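Chloro to hydrogen on the shared core: fourth compound

A few compounds are considered here, and "the series" means these few. Any claim that something is new, unique, unknown or untested is made for them only; others in the source may bear on it.

Compounds 1 to 4 share one spiro-fused core. Compound 1 `O=C1Nc2ccccc2[C@]12N[C@H](c1ccccc1)[C@H](c1ccccc1)[C@@]21CCc2c([nH]c3ccc(Cl)cc23)C1=O` was tested in a functional assay on MCF7 cells (Homo sapiens) for antiproliferative activity, read by MTT assay, with a stated time of 48 h (a lower number here means a stronger inhibitor, a higher number a weaker inhibitor), and compound 1 gives 18000 nM. Compound 2 `O=C1Nc2ccccc2[C@]12N[C@H](c1ccccc1)[C@H](c1ccccc1)[C@@]21CCc2c([nH]c3ccccc23)C1=O` differs from compound 1 by hydrogen in place of chloro on an aromatic carbon and in this assay compound 2 gives 15000 nM; the step is a 1.2-fold lower number from compound 1 to compound 2 (0.08 log units; within the scatter). Compound 3 `COc1ccc([C@H]2[C@@H](c3ccccc3)N[C@@]3(C(=O)Nc4ccccc43)[C@]23CCc2c([nH]c4ccc(Cl)cc24)C3=O)cc1` differs from compound 1 by methoxy in place of hydrogen on an aromatic carbon, and in this assay compound 3 gives 19000 nM, a step of a 1.1-fold higher number from compound 1 to compound 3 (0.02 log units; within the scatter). All three numbers sit within the usual scatter of one another, so no order among them is claimed.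

Compound 4 `COc1ccc([C@H]2[C@@H](c3ccccc3)N[C@@]3(C(=O)Nc4ccccc43)[C@]23CCc2c([nH]c4ccccc24)C3=O)cc1` has not been measured. It differs from compound 3 by hydrogen in place of chloro on an aromatic carbon, the same change as that between compound 1 and compound 2, at a place described in the same words. Among the measured compounds shown here, the difference between the two cores is the one already described for compound 1 and compound 3. Because the earlier instance of this change gave a 1.2-fold lower number from compound 1 to compound 2 (0.08 log units; within the scatter), the step from compound 3 to compound 4 is expected to be a 1.2-fold lower number from compound 3 to compound 4 (0.07 log units; within the scatter), small and within the scatter. The value expected for compound 4 in this assay is 16000 nM, estimated to fall between 8000 nM and 32000 nM.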

Compound 4, half-maximal inhibitory concentration: 17000 nM
Estimate against measurement, compound 4: 1.1-fold (0.03 log units) below, and the stated range covers the measured number.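

In this assay, replacing chloro with hydrogen on the methoxy-bearing core gives a 1.1-fold lower number from compound 3 to compound 4 (0.05 log units; within the scatter), and this agrees with the step on the core of compound 1: the same change on two cores in this assay, a 1.2-fold lower number (0.08 log units; within the scatter) from compound 1 to compound 2 and a 1.1-fold lower number (0.05 log units; within the scatter) from compound 3 to compound 4, 1.1-fold (0.03 log units) apart, within the scatter of two such steps The methoxy change, read on the core without chloro, gives a 1.1-fold higher number from compound 2 to compound 4 (0.05 log units; within the scatter), and it also agrees with its earlier instance: the same change on two cores in this assay, a 1.1-fold higher number (0.02 log units; within the scatter) from compound 1 to compound 3 and a 1.1-fold higher number (0.05 log units; within the scatter) from compound 2 to compound 4, 1.1-fold (0.03 log units) apart, within the scatter of two such steps Each change therefore carries between these two cores as a step within the scatter, but this is a weak test of transfer, since steps this small would agree even if neither change had any real effect on the number, and it shows neither an effect of chloro or methoxy nor transfer to any other core.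

The compounds shown leave open whether an amine or a carboxylic acid in place of the chloro, or a longer chain in place of the methoxy, would give a step beyond the scatter. They also leave open whether such a larger step would carry between these cores as closely as these small ones do.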